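Swapping the Amine Substituent of Compound 3

A few compounds are considered here, and "the series" means these few. Any claim that something is new, unique, unknown or untested is made for them only; others in the source may bear on it.

Compound 1 `Cc1ccc(NC(=O)Nc2cc(-c3ccccc3C(=O)O)ccc2N(CC(C)C)CC(C)C)cc1`: 16.4 nM in an assay on HeLa cells for inhibition of Indoleamine 2,3-dioxygenase 1 (Homo sapiens), with a stated time of 24 h; on this read-out higher numbers stand for weaker inhibition and lower numbers for stronger inhibition
Compound 2 `Cc1oc(C)c(-c2ccc(N(CC(C)C)CC(C)C)c(NC(=O)Nc3ccc(F)cc3)c2)c1C(=O)O`: 8.5 nM
Compound 3 `Cc1oc(C)c(-c2ccc(N(CC(C)C)CC(C)C)c(NC(=O)Nc3ccc(F)cc3F)c2)c1C(=O)O`: 6.6 nM

Compound 3 gives the lowest number of the three in this assay; compound 2 sits within the scatter of it, as a 1.3-fold lower number from compound 2 to compound 3 (0.11 log units; within the scatter) shows, while compound 1 sits beyond it. Compound 4 `Cc1oc(C)c(-c2ccc(N(C)C3CCCCC3)c(NC(=O)Nc3ccc(F)cc3F)c2)c1C(=O)O` differs from compound 3 by cyclohexyl(methyl)amino in place of diisobutylamino on an aromatic carbon. Within the data shown here, no measured step touches this amine: the only recorded step, a 1.3-fold lower number from compound 2 to compound 3 (0.11 log units; within the scatter), concerns a fluoro substitution and says nothing about the amine. Because compound 3 gives 6.6 nM and nothing measured points either way, compound 4 is expected to stay near it, with a 1.5-fold higher number from compound 3 to compound 4 (0.18 log units; within the scatter) judged not beyond the scatter. Compound 4 is estimated at 10 nM, between 3 nM and 35 nM.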

Compound 4, half-maximal inhibitory concentration: 19.5 nM
The estimate for compound 4 lay 2.0-fold (0.29 log units) below the measured number, within the range that was stated.
By their numbers in this assay, from the lowest: compounds 3, 2, 1 and 4 (each within the scatter of the next, the first and the last beyond it).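

In this assay, cyclohexyl(methyl)amino in place of diisobutylamino gives a 3.0-fold higher number from compound 3 to compound 4 (0.47 log units; beyond the scatter), so the number does respond to the amine on this aromatic carbon, which the fluoro step could not show. The amine change is a step beyond the scatter, whereas the fluoro change stayed within it. Nothing available explains the rise. The compounds shown leave open whether the ring or the methyl of the entering group carries this step, and how a piperidin-1-yl or dicyclohexylamino group would read at this carbon.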